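The compounds below may be only part of what the source reports. "The series", "measured", "known", "first", "only" and "open" are said of these compounds alone.

Working notes on the series. Compound 2, `COc1cc(C(=O)N2C[C@H](C)OC[C@@H]2CCO)cc2nc(N[C@H](C)c3cccc(Cl)c3)oc12`, holds the higher of the two numbers recorded so far in an assay on isolated protein for inhibition of thyroid hormone receptor beta (Homo sapiens), read by fluorescence, with a stated time of 30 min; a lower number here means a stronger inhibitor, a higher number a weaker inhibitor: compound 2 gives 4 nM, while compound 1, `COc1cc(C(=O)N2CC(C)(CCO)OC[C@H]2C)cc2nc(N[C@H](C)c3cccc(Cl)c3)oc12`, gives 0.5 nM. Among the compounds with values here, the single step between measured compounds, an 8.0-fold higher number from compound 1 to compound 2 (0.90 log units; beyond the scatter), replaces the 2-(2-hydroxyethyl)-2,5-dimethylmorpholin-4-yl group by the 5-(2-hydroxyethyl)-2-methylmorpholin-4-yl group on the carbonyl carbon, so compound 2 stands at the weak end of what has been measured.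

Compound 3, `COc1cc(C(=O)N2C[C@@H](C)OC[C@H]2CCO)cc2nc(N[C@H](C)c3cccc(Cl)c3)oc12`, is the next case. Its change from compound 2 is the two compounds have the same atoms and bonds and differ only in configuration as drawn: 2 of 3 stereo elements differ; a stereocentre at a saturated ring carbon is drawn S in compound 2 and R in compound 3; a stereocentre at a saturated ring carbon is drawn S in compound 2 and R in compound 3: the same atoms and bonds, with the two saturated ring carbons of the 5-(2-hydroxyethyl)-2-methylmorpholin-4-yl group drawn in the opposite configuration and the remaining stereo element kept.

Within the data shown here, no measured step in this assay concerns a change of configuration alone; the step of an 8.0-fold higher number from compound 1 to compound 2 (0.90 log units; beyond the scatter) alters the substituents of the ring and does not bear directly on this inversion. The data thus give no direction, and a step of either sign, possibly beyond the scatter, cannot be excluded. As a working figure, compound 3 is expected to give about 6 nM in this assay, within 1.5 nM to 30 nM. This estimate corresponds to an expected step of a 1.5-fold higher number from compound 2 to compound 3 (0.18 log units; within the scatter).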

Compound 3, half-maximal inhibitory concentration: 6 nM
Compound 3: middle estimate and measured number agree at the digits printed, within the range that was stated.
By their numbers in this assay, from the lowest: compound 1; then compounds 2 and 3 (each within the scatter of the next).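

Inverting both saturated ring carbons of the 5-(2-hydroxyethyl)-2-methylmorpholin-4-yl group gives the first reading on configuration in this assay: a 1.5-fold higher number from compound 2 to compound 3 (0.18 log units; within the scatter), so the two drawn forms cannot be told apart in this assay. The gap to compound 1 is therefore not confined to one drawn form, as a 12-fold higher number from compound 1 to compound 3 (1.08 log units; beyond the scatter) sits alongside an 8.0-fold higher number from compound 1 to compound 2 (0.90 log units; beyond the scatter), and both of these steps lie beyond the scatter. The comparison of the two drawn forms is a clean test of configuration, with no change of substituent mixed into it: the fact that compounds 2 and 3 differ only in the configuration as drawn.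

The compounds shown leave open whether inverting only one of the two saturated ring carbons would give the same result, and whether the gap to compound 1 follows the second methyl group or the different place of the 2-hydroxyethyl chain, since the 2-(2-hydroxyethyl)-2,5-dimethylmorpholin-4-yl group differs from the 5-(2-hydroxyethyl)-2-methylmorpholin-4-yl group in both respects. As far as these compounds go, how a carboxylic acid, a primary amine or a longer chain in place of the 2-hydroxyethyl chain would read in this assay also remains open.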